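A Second Methoxy on Compound 3

A few compounds are considered here, and "the series" means these few. Any claim that something is new, unique, unknown or untested is made for them only; others in the source may bear on it.

In a functional assay on PC-3 cells (Homo sapiens) for antiproliferative activity, read by MTT assay, with a stated time of 48 h (on this read-out lower numbers stand for stronger inhibition and higher numbers for weaker inhibition), compound 3 (`COc1ccc(-c2nnc(-c3cn4cccc(C)c4n3)o2)cc1`) gives 11800 nM and so sits level with compound 1 (`COc1ccc(-c2nnc(-c3cn4ccccc4n3)o2)cc1`) at 13400 nM while compound 2 (`Cc1cccn2cc(-c3nnc(-c4ccc(Br)cc4)o3)nc12`) shows the higher number of 37800 nM here. Compound 4 (`COc1ccc(-c2nnc(-c3cn4cccc(C)c4n3)o2)cc1OC`) has methoxy in place of hydrogen on an aromatic carbon, ortho to a methoxy group (methoxy in place of hydrogen on an aromatic carbon). Within the data shown here, two measured steps bear on this change. Methyl in place of hydrogen gave a 1.1-fold lower number from compound 1 to compound 3 (0.06 log units; within the scatter) and methoxy in place of bromo gave a 3.2-fold lower number from compound 2 to compound 3 (0.51 log units; beyond the scatter) on the ring that changes now. Neither tests a second methoxy directly, so the expected change in this assay is small, slightly downward and within the scatter, namely a 1.2-fold lower number from compound 3 to compound 4 (0.07 log units; within the scatter) as estimated. Compound 4 is expected near 10000 nM (estimated range 4000 nM to 25000 nM).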

Compound 4, half-maximal inhibitory concentration: 11500 nM
Estimate against measurement, compound 4: 1.2-fold (0.06 log units) below; the range from low to high includes it.
By their numbers in this assay, from the lowest: compounds 4, 3 and 1 (each within the scatter of the next); then compound 2.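

The earlier steps shown here touched this ring only by swapping bromo for methoxy; here a second methoxy is added, ortho to a methoxy group, and this assay shows a 1.0-fold lower number from compound 3 to compound 4 (0.01 log units; within the scatter) for that addition. This aromatic carbon therefore accepts the extra methoxy with no shift that stands out from the scatter. No measurement at hand explains this outcome.

As far as these compounds go, whether this carbon stays as unresponsive to other groups remains open, since an amine or a carboxylic acid in place of the second methoxy could give a different number.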